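The source may hold more compounds than are shown below. What is called first, only, known or untested is meant among the compounds shown, and "the series" means these compounds.

Measured in an ADME assay on microsomes from liver (Mus musculus) for metabolic stability, with a stated time of 10 min, tested at 0.5 uM; a lower number here means that less of the compound is left, a higher number that more of the compound is left:
Compound 1 `C[C@@H](NS(=O)(=O)c1ccc(Cl)cc1)[C@H]1CC[C@@H](c2ccnc3ccc(F)cc32)CC1` gives < 1%, which is a limit of the assay and not a number.
Compound 2 `C[C@@H](NC(=O)c1cccc(Cl)c1)[C@H]1CC[C@@H](c2ccnc3ccc(F)cc32)CC1` gives 9%.

Within the data shown here, compound 2 holds the only actual number in this assay. Compound 3 `C[C@@H](NC(=O)c1ccccc1Cl)[C@H]1CC[C@@H](c2ccnc3ccc(F)cc32)CC1` differs from it by 2-chlorophenyl in place of 3-chlorophenyl on a carbonyl carbon, with 2-chlorophenyl in place of 3-chlorophenyl on a carbonyl carbon. Among the measured compounds shown here, the one measured step, a number at least 8 percentage points higher from compound 1 to compound 2 (that floor lies within the scatter), exchanges a whole group on an amine nitrogen, and no measured step moves the chlorine alone. No change beyond the scatter is therefore expected, and the estimated step is a number 1 percentage points higher from compound 2 to compound 3 (within the scatter). Compound 3 is expected at 10%, within an estimated range of 2% to 25%.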

Compound 3, percent of the compound remaining: 7%
For compound 3 the middle estimate is 3 percentage points above the measured one; measured number inside the range.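

Placing 2-chlorophenyl in place of 3-chlorophenyl on a carbonyl carbon gives a number 2 percentage points lower from compound 2 to compound 3 (within the scatter) in this assay, the first measured step that moves the chlorine alone. The exchange of (4-chlorophenyl)sulfonyl for (2-chlorophenyl)carbonyl on an amine nitrogen gives a number at least 6 percentage points higher from compound 1 to compound 3 (that floor lies within the scatter) and so repeats the earlier exchange. The value of compound 1 is a limit of the assay and not a number, so this step has only a floor: the limit of < 1% in this assay, at which 1 of the 3 values shown sits.

Going by these compounds, it remains open whether a carboxylic acid or an amine in place of the chlorine would leave more of the compound in this assay.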